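The source may report more compounds than this note shows. Statements on the series, on what has been measured and on what is new or still open speak of the compounds shown alone.

In a functional assay on A549 cells (Homo sapiens) for inhibition, read by sulforhodamine B assay, with a stated time of 72 h (a higher number here means a weaker inhibitor of growth, a lower number a stronger inhibitor of growth), compound 1 `CCOC(=O)/C=C/c1ccncc1-c1ccc2c(cnn2C)c1` gives 5030 nM and compound 2 `COC(=O)/C=C/c1ccncc1-c1ccc2ccccc2c1` gives 760 nM. Compound 2 therefore holds the lower of the two numbers, with a gap beyond the scatter. Compound 3 `O=C(/C=C/c1ccncc1-c1ccc2ccccc2c1)NC1CC1` differs from compound 2 by cyclopropylamino in place of methoxy on a carbonyl carbon, with cyclopropylamino in place of methoxy on a carbonyl carbon. Among the compounds with values here, no measured pair shows this change, so the expectation is tentative. A modest move toward weaker growth inhibition in this assay is expected, estimated as a 2.0-fold higher number from compound 2 to compound 3 (0.30 log units; within the scatter). For compound 3 the estimated value is 1500 nM, with an expected range of 350 nM to 6000 nM.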

Compound 3, concentration for 50% growth inhibition: 5840 nM
The estimate for compound 3 lay 3.9-fold (0.59 log units) below the measured number, within the range that was stated.
By their numbers in this assay, from the lowest: compound 2; then compounds 1 and 3 (each within the scatter of the next).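

In this assay cyclopropylamino in place of methoxy on a carbonyl carbon gives a 7.7-fold higher number from compound 2 to compound 3 (0.89 log units; beyond the scatter) and shows that growth inhibition responds to the group at this place. Of this pair, the methoxycarbonyl compound 2 keeps the lower number. The data at hand offer no explanation for this step.

As far as these compounds go, whether the step follows from the amide hydrogen or from the cyclopropyl ring remains open. Methylamino, dimethylamino or a free carboxylic acid on the same carbonyl carbon would help separate these two features.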